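This account rests on a few compounds, and the source may have more. Where it says the series, first, only, none or still open, it means among the compounds named here.

Compound 1 `COc1cccc(/C=C2\CCC/C(=C\c3ccccc3Cl)C2=O)c1OC`: 11700 nM
Compound 2 `COc1ccccc1/C=C1\CCC/C(=C\c2cccc(OC)c2OC)C1=O`: 14100 nM

Among the compounds with values here, in a functional assay on HT-1080 cells (Homo sapiens) for cytotoxicity, read by MTT assay, with a stated time of 72 h (on this read-out higher numbers stand for weaker inhibition and lower numbers for stronger inhibition), compound 2 stands level with compound 1, the only other measured compound, and the two cannot be told apart within the usual scatter. Compound 3 `COc1cccc(/C=C2\CCC/C(=C\c3cccc(O)c3)C2=O)c1OC` is not yet measured. It differs from compound 2 as follows: 3-hydroxyphenyl in place of 2-methoxyphenyl on a double-bonded chain carbon bound to a double-bonded ring carbon. That is, it has 3-hydroxyphenyl in place of 2-methoxyphenyl on a double-bonded chain carbon bound to a double-bonded ring carbon. Within the data shown here, only one measured step bears on this change, a 1.2-fold higher number from compound 1 to compound 2 (0.08 log units; within the scatter), where methoxy replaces chloro on an aromatic carbon. Among the measured compounds shown here, that swap stayed within the scatter, but no measured compound carries 3-hydroxyphenyl, so the evidence is thin and points in neither direction. The expected change is a 1.2-fold lower number from compound 2 to compound 3 (0.07 log units; within the scatter), which means no clear step beyond the scatter is expected. For compound 3 the estimate is 12000 nM, with an expected range from 4000 nM to 30000 nM.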

Compound 3, half-maximal inhibitory concentration: 8500 nM
Compound 3: middle estimate off by 1.4-fold (0.15 log units), on the high side; low and high end bracket the measured number.
By their numbers in this assay, from the lowest: compounds 3, 1 and 2 (each within the scatter of the next).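

Placing 3-hydroxyphenyl on a double-bonded chain carbon bound to a double-bonded ring carbon brings in a hydrogen-bond donor, which 2-methoxyphenyl does not have, yet this assay shows a 1.7-fold lower number from compound 2 to compound 3 (0.22 log units; within the scatter) and also a 1.4-fold lower number from compound 1 to compound 3 (0.14 log units; within the scatter) with the 2-chlorophenyl group as the starting point. Both steps stay within the scatter, so 2-chlorophenyl, 2-methoxyphenyl and 3-hydroxyphenyl cannot be told apart at this place in this cell test, and adding the donor produces no clear shift in the number. No measurement is available that would explain this closeness.

The compounds shown leave open whether a clear step would appear with an amine or a carboxylic acid on the aromatic ring at this place, or with a longer chain in place of the ring. Within the data shown here, they also leave open whether the hydroxy group counts for anything on its own, since no pair here differs by that group alone.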